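A few compounds are considered here, and "the series" means these few. Any claim that something is new, unique, unknown or untested is made for them only; others in the source may bear on it.

Working notes on the pyrrolidine-triol series.

Of the compounds shown here, three have been measured in an assay on isolated protein for inhibition of lysosomal alpha-glucosidase (Rattus norvegicus), read by colorimetric assay; on this read-out lower numbers stand for stronger inhibition and higher numbers for weaker inhibition. Compound 1 `OC[C@]1(c2ccc(F)cc2)NC[C@H](O)[C@H]1O` gives 101000 nM. Compound 2 `OC[C@@]1(c2ccc(O)cc2)NC[C@@H](O)[C@@H]1O` gives 11000 nM, the lowest of the three numbers; the nearest is compound 1, the furthest is compound 3, and both gaps lie beyond the scatter. Compound 3 `OC[C@@]1(c2cccc(F)c2)NC[C@@H](O)[C@@H]1O` gives 216000 nM.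

The next compound to be measured is compound 4 `OC[C@@]1(c2ccc(F)cc2)NC[C@@H](O)[C@@H]1O`. Relative to compound 2 the change is fluoro in place of hydroxy on an aromatic carbon. Among the compounds with values here, no step between two measured compounds that differ in exactly one place is available, so the size of the change in this assay has not been seen directly. Within the data shown here, compound 2 stands apart from the other two compounds, and its value 11000 nM is the only one carrying the hydroxy group; the two fluoro-bearing compounds both give higher numbers. On that basis the expected step is toward a higher number, beyond the scatter: a 5.5-fold higher number from compound 2 to compound 4 (0.74 log units; beyond the scatter) is the expected step. Compound 4 is estimated at 60000 nM, within a range of 15000 nM to 250000 nM.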

Compound 4, half-maximal inhibitory concentration: 12000 nM
For compound 4 the middle estimate is 5.0-fold (0.70 log units) above the measured one, and the stated range ends above it.
By their numbers in this assay, from the lowest: compounds 2 and 4 (each within the scatter of the next); then compound 1; then compound 3.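

In this assay fluoro in place of hydroxy on the aromatic carbon gives a 1.1-fold higher number from compound 2 to compound 4 (0.04 log units; within the scatter) and so leaves the read-out level, which means the hydroxy group is not what sets compound 2 apart from the fluoro-bearing compounds. At this position the two groups cannot be told apart in this assay. The mirror-image pair gives an 8.4-fold lower number from compound 1 to compound 4 (0.93 log units; beyond the scatter) and puts the gap on configuration alone: the fact that compounds 1 and 4 differ only in the configuration as drawn

As far as these compounds go, whether configuration matters as much with hydroxy on the aromatic ring stays open. Also open, from the compounds shown here alone, is whether an amine or a methoxy group on the same aromatic carbon would stay level with hydroxy and fluoro, or whether a carboxylic acid there would shift the number.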